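Chloro for fluoro on the pyridine of compound 2

This account rests on a few compounds, and the source may have more. Where it says the series, first, only, none or still open, it means among the compounds named here.

Measured so far:
compound 1, `Clc1ccc(C2=CC3CNCC(C2)C3)cn1`, 0.4 nM
compound 2, `CN1CC2C=C(c3ccc(F)nc3)CC(C2)C1`, 18 nM

Of the compounds shown here, two have been measured in an in vitro assay on SH-EP1 cells for displacement of a labelled ligand from Neuronal acetylcholine receptor; alpha4/beta2 (Homo sapiens); on this read-out lower numbers stand for stronger inhibition and higher numbers for weaker inhibition. Compound 1, with a free amine on its bicyclic core and a chloro group on the pyridine, gives 0.4 nM. Compound 2, which carries a methyl on that amine and a fluoro group on the pyridine, gives 18 nM. Of the two numbers, compound 2 has the higher one, and the gap to compound 1 lies beyond the scatter; since the two compounds differ in two places, the two values show only that much.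

Compound 3, `CN1CC2C=C(c3ccc(Cl)nc3)CC(C2)C1`, is the next to be measured in this assay. It keeps the methylated amine of compound 2 and differs from it in one place: chloro in place of fluoro on an aromatic carbon. Among the measured compounds shown here, since no single-change step between measured compounds covers a chloro-for-fluoro swap, the size of the step is open. Given that compound 1, the chloro analogue, gives 0.4 nM, a moderate move toward lower numbers is expected from compound 2 to compound 3, a 2.6-fold lower number from compound 2 to compound 3 (0.41 log units; beyond the scatter). Compound 3 is therefore estimated at 7 nM, within a range of 2 nM to 25 nM.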

Compound 3, inhibition constant: 22 nM
Estimate against measurement, compound 3: 3.1-fold (0.50 log units) below; the range from low to high includes it.
By their numbers in this assay, from the lowest: compound 1; then compounds 2 and 3 (each within the scatter of the next).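

In this assay, chloro in place of fluoro on the aromatic carbon next to the ring nitrogen gives a 1.2-fold higher number from compound 2 to compound 3 (0.09 log units; within the scatter) and so, with a methyl on the amine nitrogen, this position does not separate the two halogens. With chloro held constant, methyl in place of hydrogen on the amine nitrogen in the ring gives a 55-fold higher number from compound 1 to compound 3 (1.74 log units; beyond the scatter) and thus a large step, which places the change in this pair at the amine nitrogen alone. No measurement shown here explains either step.

The compounds shown leave open whether chloro and fluoro would also lie within the scatter of each other on the core with the free amine, and whether the same flat picture would hold for other groups at this position, such as a bromo, a methoxy or a nitrile. They also do not tell how a longer chain on the amine nitrogen, such as an ethyl, would compare with the methyl and with the hydrogen.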